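The source may report more compounds than this note shows. Statements on the series, on what has been measured and on what is new or still open speak of the compounds shown alone.

Compound 1 `Cc1nc(-c2ccccc2)c(C(=O)N2CCN(c3cccc(Cl)c3)CC2)o1`: 39.2 nM
Compound 2 `CC(=O)c1ccc(N2CCN(C(=O)c3oc(C)nc3-c3ccccc3)CC2)cc1`: "not active" (no number reported)

Among the compounds with values here, in a functional assay on HL-60 cells (Homo sapiens) for inhibition, read by MTT assay, with a stated time of 72 h (a higher number here means a weaker inhibitor, a lower number a stronger inhibitor), compound 1 gives 39.2 nM, the only number reported in this assay. Compound 2 carries a different group on the piperazine nitrogen, and in this assay compound 2 is reported without a number, as "not active" (no number reported). Within the data shown here, no step between two measured compounds is available, so the effect of any single change on the read-out is not known from these data.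

Compound 3 `COc1cc(-c2nc(C)oc2C(=O)N2CCN(c3cccc(Cl)c3)CC2)ccc1O` has not yet been measured. It differs from compound 1 in one place: 4-hydroxy-3-methoxyphenyl in place of phenyl on an aromatic carbon. The shared core of compound 1 and the chlorophenyl-piperazine amide are kept.

Among the measured compounds shown here, with no measured step to rest on, only a cautious expectation is possible. The change is larger than a simple substitution but leaves the rest of the molecule untouched, and one would expect a step that stays near or only a little beyond the usual scatter, more likely toward weaker inhibition than toward stronger. Compound 3 is therefore estimated at 65 nM in this assay, with a range of 15 nM to 280 nM, which means an expected step of a 1.7-fold higher number from compound 1 to compound 3 (0.22 log units; within the scatter).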

Compound 3, half-maximal inhibitory concentration: 85.9 nM
Estimate against measurement, compound 3: 1.3-fold (0.12 log units) below; low and high end bracket the measured number.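

In this assay, within the data shown here, replacing phenyl with 4-hydroxy-3-methoxyphenyl on the aromatic carbon next to the ring nitrogen gives a 2.2-fold higher number from compound 1 to compound 3 (0.34 log units; beyond the scatter), the first step in these data that can be read as a number. The position therefore accepts this larger group, which brings in a hydroxyl and a methoxy, at only a modest cost: compound 3 still gives 85.9 nM and remains well within the measurable range of this assay, while the chlorophenyl-piperazine amide stays unchanged. Nothing at hand explains why the number rises by this amount.

The compounds shown do not separate the two added groups, so it remains open whether 4-hydroxyphenyl or 3-methoxyphenyl alone would account for the step, or whether a group such as 4-aminophenyl or 4-carboxyphenyl would be accepted at this position in the same way. As far as these compounds go, it also remains open whether the same change would give a similar step on a compound with a different group on the piperazine nitrogen.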